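A side-chain exchange from compound 3 to compound 4

A few compounds are considered here, and "the series" means these few. Any claim that something is new, unique, unknown or untested is made for them only; others in the source may bear on it.

Of the compounds shown here, three have been measured in a functional assay on the whole organism for inhibition, with Rattus norvegicus as the target; on this read-out lower numbers stand for an effect already at smaller amounts and higher numbers for an effect only at larger amounts of compound. Compound 1 `O=C(O)[C@@H](c1ccc(OCc2ccc3ccccc3n2)cc1)C1CCCC1` gives 4 mg/kg, compound 2 `C/C(=N\OC(c1ccc(OCc2ccc3ccccc3n2)cc1)C1CCCCCC1)C(=O)O` gives 0.7 mg/kg and compound 3 `C/C(=N\OC(CC(C)(C)c1ccccc1)c1ccc(OCc2ccc3ccccc3n2)cc1)C(=O)O` gives 2 mg/kg. Compound 3 therefore lies within the scatter of compound 1, while its number stands beyond the scatter above that of compound 2.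

The next compound, compound 4 `C/C(=N\OC(CCCc1ccc(F)cc1)c1ccc(OCc2ccc3ccccc3n2)cc1)C(=O)O`, alters the side chain of compound 3: 2-(4-fluorophenyl)ethyl in place of 1-methyl-1-phenylethyl on a saturated chain carbon, two bonds along the chain from an aromatic carbon and an oxygen. Cut one bond further out, the same difference reads 2-methyl-2-phenylpropyl to 3-(4-fluorophenyl)propyl. For the measured compounds named here, the only measured step at this side chain is a 2.9-fold higher number from compound 2 to compound 3 (0.46 log units; beyond the scatter), a modest change, with 2-methyl-2-phenylpropyl in place of cycloheptyl. Going by the values given here, compound 1 differs from the others in more than one place and provides no such step. No measurement isolates the present exchange, and none fixes its direction. Since replacing cycloheptyl moved the number only modestly, a step no larger than that one is expected here, most likely within the scatter. The estimated step is a 1.3-fold lower number from compound 3 to compound 4 (0.12 log units; within the scatter). Compound 4 is estimated at 1.5 mg/kg in this assay, with an expected range from 0.5 mg/kg to 4 mg/kg.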

Compound 4, dose for half-maximal effect: 2.6 mg/kg
Compound 4: middle estimate off by 1.7-fold (0.24 log units), on the low side; the range from low to high includes it.
By their numbers in this assay, from the lowest: compound 2; then compounds 3, 4 and 1 (each within the scatter of the next).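

In this assay the exchange of 1-methyl-1-phenylethyl for 2-(4-fluorophenyl)ethyl gives a 1.3-fold higher number from compound 3 to compound 4 (0.11 log units; within the scatter) at this saturated chain carbon, so the data do not separate these two groups, although the branched chain gives way to an unbranched one and a fluorine enters. Both side chains hold 9 heavy atoms and one six-membered aromatic ring of carbon only, and at this place the read-out tolerates the difference in their shape and substitution as far as these two compounds go. Measured against the cycloheptyl group, the 3-(4-fluorophenyl)propyl group gives a 3.7-fold higher number from compound 2 to compound 4 (0.57 log units; beyond the scatter) in the same assay, so compound 2 now stands apart from two different aryl-bearing side chains, not just one, and no information at hand explains these numbers.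

The compounds shown leave open what the fluorine and the loss of the two methyl groups each contribute alone, as both arrive in one exchange, and a propyl chain ending in a plain phenyl would part them. They also leave open how this position would answer to a cyclohexyl group or to a chain carrying a hydroxyl or an amine.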